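Replacing a pyridinyl Ring with a Cycloheptenyl Ring

This account rests on a few compounds, and the source may have more. Where it says the series, first, only, none or still open, it means among the compounds named here.

Compound 1: `CC[C@H](C)[C@H](N)CN(C(=O)[C@@H]1C[C@H]1c1ccc(F)cc1F)c1ccc(-c2ccccc2)cc1` gives 1300 nM in a functional assay for agonist activity at G protein-coupled receptor 88 (Homo sapiens), read by HTRF and cAMP accumulation; a higher number here means that more compound is needed for the effect, a lower number that less compound is needed.
Compound 2: `CC(C)C[C@H](N)CN(C(=O)[C@@H]1C[C@H]1c1ccccc1)c1ccc(-c2ccncc2)cc1` gives 13000 nM in this assay.

Of the two measured compounds, compound 2 stands at the higher end: its number in this assay is above that of compound 1, and the gap between them lies beyond the usual scatter of repeated measurements. The two differ at several places at once, so nothing can be drawn from them about any single group.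

Compound 3, `CC(C)C[C@H](N)CN(C(=O)[C@@H]1C[C@H]1c1ccccc1)c1ccc(C2=CCCCCC2)cc1`, has not yet been measured. It differs from compound 2 in one place only: cyclohept-1-en-1-yl in place of pyridin-4-yl on an aromatic carbon. The aromatic ring with a nitrogen atom on the shared core is thus exchanged for a seven-membered non-aromatic ring of carbon only, para to a large group.

Among the measured compounds shown here, no measured pair shows this change, so its size is not known from the data. Given how high compound 2 stands with 13000 nM, a move to a lower number in this assay is expected for compound 3, of the size a 4.3-fold lower number from compound 2 to compound 3 (0.64 log units; beyond the scatter). The expected value for compound 3 is 3000 nM, within a range from 700 nM to 13000 nM.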

Compound 3, half-maximal effective concentration: 2100 nM
Compound 3: the middle estimate sits 1.4-fold (0.15 log units) above what was measured; the range from low to high includes it.
By their numbers in this assay, from the lowest: compounds 1 and 3 (each within the scatter of the next); then compound 2.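

Among the compounds shown here, with compound 3, a change at a single place can be read for the first time: at the aromatic carbon para to a large group, cyclohept-1-en-1-yl in place of pyridin-4-yl gives a 6.2-fold lower number from compound 2 to compound 3 (0.79 log units; beyond the scatter) in this assay. This position therefore tolerates the loss of the aromatic ring with a nitrogen atom: a seven-membered non-aromatic ring of carbon only, with no hydrogen-bond acceptor, stands there and the number goes down rather than up. Nothing at hand gives a reason for this step.

The exchange alters ring size, aromatic character and the ring nitrogen all at once, and the compounds shown do not separate these; cyclohex-1-en-1-yl or a saturated cycloheptyl group at the same place would be needed to tell them apart. Going by these compounds, whether the step would carry over to the core of compound 1, which differs from compound 3 in several places, also stays open.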